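From 3-methylthiophen-2-yl to 2-chlorophenyl: working notes

The source may hold more compounds than are shown below. What is called first, only, known or untested is meant among the compounds shown, and "the series" means these compounds.

In a functional assay on MGC-803 cells (Homo sapiens) for antiproliferative activity, read by MTT assay, with a stated time of 72 h (on this read-out lower numbers stand for stronger inhibition and higher numbers for weaker inhibition), compound 1 `Cc1ccc(-c2nc(CNc3ccc(C(=O)NO)cc3)n(-c3ccccc3)n2)cc1` gives > 20000 nM, which is a limit of the assay and not a number. Among the compounds with values here, compound 2 `Cc1ccsc1-c1nc(CNc2ccc(C(=O)NO)cc2)n(-c2ccccc2)n1` gives 8890 nM, the only true number so far. Compound 3 `O=C(NO)c1ccc(NCc2nc(-c3ccccc3Cl)nn2-c2ccccc2)cc1` carries 2-chlorophenyl in place of 3-methylthiophen-2-yl on an aromatic carbon. Within the data shown here, the one measured step at this place is an at least 2.2-fold lower number from compound 1 to compound 2 (0.35 log units; beyond the scatter), bounded on one side only by the limit of > 20000 nM in this assay, at which 1 of the 2 values shown sits. Compound 1 also carries a six-membered aromatic ring of carbon only, so a small move toward weaker inhibition is expected in this assay. The expected step is a 1.3-fold higher number from compound 2 to compound 3 (0.13 log units; within the scatter). The estimate for compound 3 is 12000 nM, with a range of 4500 nM to 30000 nM.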

Compound 3, half-maximal inhibitory concentration: > 20000 nM
Compound 3: only a limit was reported; the forecaster's own chance of this, stated with the estimate: 35%; middle value at least 1.6-fold (0.22 log units) away from the limit.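

In this assay, 2-chlorophenyl in place of 3-methylthiophen-2-yl on this aromatic carbon gives an at least 2.2-fold higher number from compound 2 to compound 3 (0.35 log units; beyond the scatter), so a second six-membered aromatic ring of carbon only joins 4-methylphenyl in giving no true number, and 3-methylthiophen-2-yl alone gives one. Compound 1 and compound 3 each stand at a limit of the assay and not at a number, so the step between them cannot be read. The size of the step to compound 3 stays bounded on one side only: the limit of > 20000 nM in this assay, at which 2 of the 3 values shown sit.

Open, as far as these compounds go, is whether the ring sulfur or the five-membered ring size goes with the measurable value. Also open, from the compounds shown here alone, is whether unsubstituted phenyl, a pyridine ring or an amine at this place would give a true number.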